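Restoring a benzyloxy linkage on the shared core

The source may report more compounds than this note shows. Statements on the series, on what has been measured and on what is new or still open speak of the compounds shown alone.

Compound 1 `Cc1nn(-c2ncnc3nc[nH]c23)c2c1C(OCc1ccc(Cl)cc1Cl)CC(=O)N2`: 4 nM
Compound 2 `Cc1nn(-c2ncnc3nc[nH]c23)c2c1C(OC1CCCC1)CC(=O)N2`: 2 nM
Compound 3 `Cc1nn(-c2ncnc3nc[nH]c23)c2c1C(c1ccc(OC(C)C)cc1)CC(=O)N2`: 18 nM

In a functional assay on HEK293 cells for agonist activity at G-protein coupled receptor 39 (Homo sapiens), read by scintillation proximity assay and inositol phosphate accumulation, with a stated time of 75 min, in the presence of a further agent that is not named here (on this read-out higher numbers stand for an effect only at larger amounts of compound and lower numbers for an effect already at smaller amounts), compound 3 gives the highest of the three numbers; its nearest neighbour is compound 1, and the step of a 4.5-fold higher number from compound 1 to compound 3 (0.65 log units; beyond the scatter) is beyond the scatter, as is a 9.0-fold higher number from compound 2 to compound 3 (0.95 log units; beyond the scatter). Compound 4 `Cc1nn(-c2ncnc3nc[nH]c23)c2c1C(OCc1ccc(F)cc1)CC(=O)N2` differs from compound 3 by (4-fluorobenzyl)oxy in place of 4-isopropoxyphenyl on a saturated ring carbon. This change brings back an oxygen-linked arylmethyl group of the kind carried by compound 1, whose number sits well below that of compound 3. Both steps that bear on this, from compound 1 and from compound 2 to compound 3, were modest rises; reversing such a change should give a modest fall. Compound 4 is therefore expected to come out near compound 1, at about 5 nM (range 1.5 nM to 15 nM), a step of a 3.6-fold lower number from compound 3 to compound 4 (0.56 log units; beyond the scatter).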

Compound 4, half-maximal effective concentration: 1 nM
Beside the measured number, compound 4's estimate is 5.0-fold (0.70 log units) above it; measured number outside the range, below it.
By their numbers in this assay, from the lowest: compounds 4, 2 and 1 (each within the scatter of the next, the first and the last beyond it); then compound 3.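

In this assay, among the compounds shown here, (4-fluorobenzyl)oxy in place of 4-isopropoxyphenyl on the saturated ring carbon gives an 18-fold lower number from compound 3 to compound 4 (1.26 log units; beyond the scatter), the largest step seen at this place so far. On the oxygen-linked side, 4-fluorophenyl in place of 2,4-dichlorophenyl gives a 4.0-fold lower number from compound 1 to compound 4 (0.60 log units; beyond the scatter), beyond the scatter, while a 2.0-fold lower number from compound 2 to compound 4 (0.30 log units; within the scatter) stays within it, so 4-fluorobenzyl and cyclopentyl on this oxygen cannot be told apart. Nothing available accounts for these differences. As far as these compounds go, whether an amine, a carboxylic acid or a longer chain on this oxygen would keep such numbers remains open.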